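Aryl piperazine series: trifluoromethyl to fluoro swap

This account rests on a few compounds, and the source may have more. Where it says the series, first, only, none or still open, it means among the compounds named here.

Going by the values given here, compound 2 `N#Cc1cccc(COc2ccc(-c3cc(CN4CCN(c5ccc(C(F)(F)F)cc5)CC4)no3)cc2)c1` stands at the highest of the two numbers so far in a functional assay on Huh-7 cells (Homo sapiens) for antiproliferative activity, read by sulforhodamine B assay, with a stated time of 72 h; a lower number here means a stronger inhibitor, a higher number a weaker inhibitor: compound 2 gives 2200 nM, while compound 1 `COc1cc(COc2ccc(-c3cc(CN4CCN(Cc5ccc(C(F)(F)F)cc5)CC4)no3)cc2)cc(OC)c1` gives 1500 nM, a gap within the scatter, so no order between the two is claimed. Compound 3 `N#Cc1cccc(COc2ccc(-c3cc(CN4CCN(c5ccc(F)cc5)CC4)no3)cc2)c1` is not yet measured; it differs from compound 2 by fluoro in place of trifluoromethyl on an aromatic carbon. Among the compounds with values here, no measured step of this kind exists, so only a modest shift in this assay is expected, direction open, likely not beyond the scatter. Compound 3 is expected at 3000 nM, between 1200 nM and 8000 nM. The expected step of a 1.4-fold higher number from compound 2 to compound 3 (0.13 log units; within the scatter) stays near the scatter.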

Compound 3, half-maximal inhibitory concentration: 1500 nM
Compound 3: middle estimate off by 2.0-fold (0.30 log units), on the high side; the range from low to high includes it.
By their numbers in this assay, from the lowest: compounds 1, 3 and 2 (each within the scatter of the next).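

In this assay, this position now has its first single-place step, and a 1.5-fold lower number from compound 2 to compound 3 (0.17 log units; within the scatter) stays within the scatter. Fluoro in place of trifluoromethyl, on an aromatic carbon para to a large group, therefore gives no readable change in this assay. No measured evidence bears on this step.

As far as these compounds go, whether an amine or a carboxylic acid on the same carbon would give a step beyond the scatter remains open. Also open, from the compounds shown here alone, is whether the same swap would stay within the scatter on the core of compound 1.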